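This account rests on a few compounds, and the source may have more. Where it says the series, first, only, none or still open, it means among the compounds named here.

Compound 1 `Cc1ccc2[nH]c(-c3ccc[nH]3)c(C3CC(=O)NC3=O)c2c1` and compound 2 `COc1ccc2[nH]c(-c3ccc[nH]3)cc2c1` were tested in a functional assay on OE21 cells (Homo sapiens) for cytotoxicity, read by MTT assay, with a stated time of 72 h; a lower number here means a stronger inhibitor, a higher number a weaker inhibitor. For compound 1 the result is only a limit, > 100000 nM, so its position among the numbers is not fixed; it sits at the limit of > 100000 nM in this assay, at which 1 of the 2 values shown sits. In this assay compound 2 gives 33000 nM. Compound 3 `O=C1CC(c2c(-c3ccc[nH]3)[nH]c3ccccc23)C(=O)N1` has not been measured. It differs from compound 1 by hydrogen in place of methyl on an aromatic carbon, a change that removes one carbon and no ring. Among the compounds with values here, no step of this kind has been measured here, and compound 3 is expected to move no further than the scatter, giving a step that the limit leaves unreadable from compound 1 to compound 3. Compound 3 is therefore estimated at 150000 nM, with a range from 50000 nM to 500000 nM.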

Compound 3, half-maximal inhibitory concentration: 67000 nM
Compound 3: the middle estimate sits 2.2-fold (0.35 log units) above what was measured; the measured number falls inside the stated range.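

With hydrogen in place of methyl on the aromatic carbon, this assay now shows an at least 1.4-fold lower number from compound 1 to compound 3 (0.17 log units; that floor lies within the scatter) for this change. Compound 3 gives this position a number, whereas the value for compound 1 is only a limit: the limit of > 100000 nM in this assay, at which 1 of the 3 values shown sits. The step therefore has only a floor, and that floor does not separate hydrogen from methyl at this position.

From the compounds shown here alone, the true size of the step stays open. So does what an amine or a carboxylic acid on this aromatic carbon would give.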